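This account rests on a few compounds, and the source may have more. Where it says the series, first, only, none or still open, it means among the compounds named here.

Compound 1 `Cn1cc(-c2nc3ccccc3n2C(=O)c2ccccc2)c2ccccc21` carries an unsubstituted benzoyl group on the shared core. In a functional assay on MCF7 cells (Homo sapiens) for inhibition, read by MTT assay, with a stated time of 24 h (a higher number here means a weaker inhibitor of growth, a lower number a stronger inhibitor of growth), compound 1 gives 43700 nM. Compound 2 `COc1ccccc1C(=O)n1c(-c2cn(C)c3ccccc23)nc2ccccc21` differs from it by methoxy in place of hydrogen on an aromatic carbon, and in this assay compound 2 gives 32100 nM; the step is a 1.4-fold lower number from compound 1 to compound 2 (0.13 log units; within the scatter). Compound 3 `COc1ccc(C(=O)n2c(-c3cn(C)c4ccc(OC)cc34)nc3ccccc32)cc1` is the third measured member, and in this assay compound 3 gives 14800 nM. The difference between the core of compound 3 and the core of compound 1 is not broken down here; the two values simply show compound 3 with the lower number of the two. Compound 4 `COc1ccc2c(c1)c(-c1nc3ccccc3n1C(=O)c1ccc(OC)c(OC)c1)cn2C` has not been measured yet. It differs from compound 3 by methoxy in place of hydrogen on an aromatic carbon. This is the same kind of change as that from compound 1 to compound 2, but the surroundings differ: in the earlier case the new methoxy sits ortho to a large group, whereas here it sits ortho to a methoxy group and meta to a large group. Because the earlier change gave only a 1.4-fold lower number from compound 1 to compound 2 (0.13 log units; within the scatter), the step from compound 3 to compound 4 is expected to be small, a 1.3-fold lower number from compound 3 to compound 4 (0.13 log units; within the scatter). Compound 4 is therefore estimated at 11000 nM, with a range of 5000 nM to 25000 nM.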

Compound 4, concentration for 50% growth inhibition: 6300 nM
For compound 4 the middle estimate is 1.7-fold (0.24 log units) above the measured one; low and high end bracket the measured number.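

In this assay, going from the 4-methoxyphenyl to the 3,4-dimethoxyphenyl group gives a 2.3-fold lower number from compound 3 to compound 4 (0.37 log units; beyond the scatter) and this step lies beyond the scatter, whereas the earlier step with the same change does not. Even so, the two steps cannot be told apart, and on these two cores the change shows no measurable dependence on its surroundings: the same change on two cores in this assay, a 1.4-fold lower number (0.13 log units; within the scatter) from compound 1 to compound 2 and a 2.3-fold lower number (0.37 log units; beyond the scatter) from compound 3 to compound 4, 1.7-fold (0.24 log units) apart, within the scatter of two such steps. For the compounds shown here, this rests on only two pairs, with the new methoxy placed differently in each, and it does not show that the step keeps its size on other cores or that the change reliably lowers the number.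

The compounds shown leave open whether a different group at the same place, such as a hydroxyl, a fluorine or an amine, would shift the number in the same way as methoxy. They also leave open whether a longer chain, such as ethoxy, would give a step of similar size.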